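Aryl swap on the ring nitrogen of compound 1

The source may report more compounds than this note shows. Statements on the series, on what has been measured and on what is new or still open speak of the compounds shown alone.

Compound 1 `Cc1nc(-c2ccccc2)c(C(=O)N2CCN(c3cccc(C#N)c3)CC2)o1` is the reference point of this small set. In a functional assay on HL-60 cells (Homo sapiens) for inhibition, read by MTT assay, with a stated time of 72 h (on this read-out lower numbers stand for stronger inhibition and higher numbers for weaker inhibition), compound 1 gives 39.6 nM, the lowest of the two numbers recorded. Compound 3 `CCc1nc(-c2cccc(F)c2)c(C(=O)N2CCN(c3cccc(Cl)c3)CC2)o1` gives 317 nM in this assay, a higher number that lies beyond the usual scatter. Compound 2 `CCc1nc(-c2ccc(OC)c(OC)c2)c(C(=O)N2CCN(c3cccc(Cl)c3)CC2)o1` is reported in this assay only as "not active" (no number reported), without a number. Among the compounds with values here, no pair of measured compounds differs in just one place, so no measured step exists to guide the next comparison.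

Compound 4 `COc1cc(OC)cc(N2CCN(C(=O)c3oc(C)nc3-c3ccccc3)CC2)c1` is derived from compound 1 by one change: 3,5-dimethoxyphenyl in place of 3-cyanophenyl on an amine nitrogen in a ring. The aryl group on the amine nitrogen in the ring is thus exchanged for one carrying two methoxy groups in place of the nitrile, while the shared core and its other substituents are kept. Nothing measured in this set directly reports the effect of such an exchange at this position. A moderate shift toward a higher number is expected from compound 1 to compound 4, a 3.0-fold higher number from compound 1 to compound 4 (0.48 log units; beyond the scatter), likely beyond the scatter but not large. Compound 4 is therefore expected to give about 120 nM in this assay, with a plausible range from 30 nM to 600 nM.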

Compound 4, half-maximal inhibitory concentration: 19.2 nM
Compound 4: the middle estimate sits 6.3-fold (0.80 log units) above what was measured; measured number below the stated range.
By their numbers in this assay, from the lowest: compound 4; then compound 1; then compound 3.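

Working notes on the aryl group on the amine nitrogen in the ring: in this assay, replacing 3-cyanophenyl with 3,5-dimethoxyphenyl gives a 2.1-fold lower number from compound 1 to compound 4 (0.31 log units; beyond the scatter), the first measured single-place step in this series. The nitrile is therefore not needed for a low number at this position on the shared core, and a group with two methoxy substituents and more heavy atoms keeps the number low, with a modest step in the favourable direction. Nothing available bears on why the number falls with this exchange.

The compounds shown do not separate the loss of the nitrile from the gain of the two methoxy groups, so it remains open whether a single methoxy group, or hydroxyl groups in place of the methoxy groups, would hold the number in this assay. Going by these compounds, it also remains open whether the 3,5-dimethoxyphenyl group would give a similar step on the differently substituted cores of compound 2 and compound 3, and whether an aryl group bearing an amine or a carboxylic acid would be accepted on this ring nitrogen.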